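A chloro added to compound 2

This account rests on a few compounds, and the source may have more. Where it says the series, first, only, none or still open, it means among the compounds named here.

Measured so far in an ADME assay on HEK-293T cells (Homo sapiens) for inhibition, read by CCK-8 assay, with a stated time of 48 h, tested at 20 uM; on this read-out lower numbers stand for less inhibition of growth and higher numbers for more inhibition of growth at the one concentration tested
- compound 1 `Cc1nnc(NC(=O)/C(C#N)=C/c2cccc(OS(C)(=O)=O)c2)s1` gives 20%
- compound 2 `Cc1ccc(S(=O)(=O)Oc2cccc(/C=C(\C#N)C(=O)Nc3nnc(-c4ccccc4)s3)c2)cc1` gives 52%

In this assay compound 2 gives 52% and so stands highest of the two measured compounds, with compound 1 at 20% as its nearest neighbour, a gap beyond the usual scatter. These two compounds differ in more than one place, so their gap cannot be tied to any single change.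

The next compound, compound 3 `Cc1ccc(S(=O)(=O)Oc2cccc(/C=C(\C#N)C(=O)Nc3nnc(-c4ccccc4Cl)s3)c2)cc1`, departs from compound 2 at one place only: chloro in place of hydrogen on an aromatic carbon with chloro in place of hydrogen on an aromatic carbon, ortho to a large group, which turns phenyl to 2-chlorophenyl. Going by the values given here, no measured pair shows what this change does, so the expectation starts from compound 2 at 52% and stays cautious. A small rise is expected, with no shift beyond the scatter. The estimated step is a number 3 percentage points higher from compound 2 to compound 3 (within the scatter) in this assay and the uncertainty around it remains wide. The value expected for compound 3 is 55% (estimated range 35% to 75%).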

Compound 3, percent growth inhibition at one concentration: 55%
For compound 3 middle estimate and measured number coincide at the digits printed, within the range that was stated.
By their numbers in this assay, from the lowest: compound 1; then compounds 2 and 3 (each within the scatter of the next).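

Going by these compounds alone, this pair gives the first reading of a change at a single place, since compound 2 and compound 3 differ only by chloro in place of hydrogen on an aromatic carbon, ortho to a large group. In this assay the step is a number 3 percentage points higher from compound 2 to compound 3 (within the scatter), so turning phenyl to 2-chlorophenyl does not separate the two compounds, and this position accepts the one added chlorine atom with no measurable shift in growth inhibition at the one concentration tested. Nothing on hand bears on why the read-out stays within the scatter after this change.

As far as these compounds go, whether a methoxy group or an amine in the place of this chloro would give a step beyond the scatter remains open, as one substituent at one position cannot show how far this place tolerates change in general. The gap between compound 1 and compound 2 also cannot be read as a step, as those two differ in more than one place, so the change or changes behind it remain unidentified.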